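Ethyl ester in place of the free acid on compound 3

The compounds below may be only part of what the source reports. "The series", "measured", "known", "first", "only" and "open" are said of these compounds alone.

Measured compounds:
compound 1 `COc1cc(/C=C/C(=O)O)ccc1OC(=O)c1nc(C)c(C)nc1C` 38.7%
compound 2 `CCOC(=O)/C=C/c1ccc(OC(=O)c2nc(C)c(C)nc2C)c(O)c1` 75.7%
compound 3 `COc1cc(/C=C/C(=O)O)cc(OC)c1OC(=O)c1nc(C)c(C)nc1C` 5.7%

In a functional assay on EA.hy 926 cells (Homo sapiens) for cytotoxicity, read by MTT assay, with stated times of 24 h and 12 h, tested at 12.5 uM (a lower number here means a weaker effect, a higher number a stronger effect of the compound at the concentration tested), compound 3 gives 5.7%, the lowest of the three numbers; compound 1 lies above it by a number 33 percentage points lower from compound 1 to compound 3 (beyond the scatter), and compound 2 lies further above. Compound 4 `CCOC(=O)/C=C/c1cc(OC)c(OC(=O)c2nc(C)c(C)nc2C)c(OC)c1` differs from compound 3 by ethyl in place of hydrogen on an oxygen next to a carbonyl group. Going by the values given here, no measured pair isolates this change: the only single step, from compound 1 to compound 3, concerns a methoxy group, and compound 2, which carries the ethyl ester, differs from compound 1 in two places, so its high value cannot be assigned to the ester alone. The expectation for compound 4 is therefore a modest rise, a number 14.3 percentage points higher from compound 3 to compound 4 (beyond the scatter), with wide uncertainty. Compound 4 is estimated at 20%, between 2% and 45%.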

Compound 4, a percentage reported as activity, at one concentration (the size of the read-out at that concentration, not a potency): 96.6%
Compound 4: middle estimate off by 76.6 percentage points, on the low side, outside the stated range (above it).
By their numbers in this assay, from the lowest: compound 3; then compound 1; then compound 2; then compound 4.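

In this assay, ethyl in place of hydrogen on an oxygen next to a carbonyl group, which turns carboxy into ethoxycarbonyl, gives a number 90.9 percentage points higher from compound 3 to compound 4 (beyond the scatter) in a single change. Going by these compounds alone, this is the first pair to isolate that change, and it shows that this one position can move the read-out from near the bottom of the series to the top. Nothing measured here explains the size of this step.

The compounds shown leave open whether a methyl ester, a longer chain on that oxygen or an amide would match ethyl. They also leave open whether the same change on compound 1 would give a similar step.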